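The compounds below may be only part of what the source reports. "The series", "measured", "known", "first", "only" and "open" are said of these compounds alone.

Compound 1 `O=C(O)CC(O)(CSCCCCCc1ccc(Cl)cc1Cl)C(=O)O`: 6800 nM
Compound 2 `COc1ccc(CCCCCCSCC(O)(CC(=O)O)C(=O)O)cc1`: 280000 nM
Compound 3 `O=C(O)CC(O)(CSCCCCCCc1ccccc1Cc1ccccc1)C(=O)O`: 94000 nM

These three compounds share a common core and were measured in an assay on isolated protein for inhibition of ATP-citrate synthase (Rattus norvegicus); on this read-out higher numbers stand for weaker inhibition and lower numbers for stronger inhibition. Compound 2 stands highest of the three numbers, so it is the weakest inhibitor among them; compound 3 sits below it and compound 1 lies well below both, with each gap beyond the scatter. Compound 4 `O=C(O)CC(O)(CSCCCCCCc1ccc(F)cc1F)C(=O)O` has not yet been measured. It differs from compound 2 by 2,4-difluorophenyl in place of 4-methoxyphenyl on a saturated chain carbon, six bonds along the chain from a sulfur. No measured pair differs in only one place, so the size of this step cannot be read from a shown step. A move toward stronger inhibition nevertheless seems likely, because compound 1, whose ring also carries two halogens, gives 6800 nM in this assay. Compound 4 is estimated at 30000 nM, within a range from 8000 nM to 120000 nM. The expected step is a 9.3-fold lower number from compound 2 to compound 4 (0.97 log units; beyond the scatter), beyond the scatter.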

Compound 4, inhibition constant: 270000 nM
Estimate against measurement, compound 4: 9.0-fold (0.95 log units) below; the whole stated range lies below it.
By their numbers in this assay, from the lowest: compound 1; then compound 3; then compounds 4 and 2 (each within the scatter of the next).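

In this assay the change from 4-methoxyphenyl to 2,4-difluorophenyl on a saturated chain carbon, six bonds along the chain from a sulfur, gives a 1.0-fold lower number from compound 2 to compound 4 (0.02 log units; within the scatter) and stays within the scatter. The two groups cannot be told apart here, and the hydrogen-bond acceptor in 4-methoxyphenyl can go with no measurable change in this pair. Nothing shown offers a reason for this result. Still open, on these data alone, is whether an amine or a carboxylic acid on the ring, or a longer chain, would shift the number at all.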